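Methyl to Vinyl on a Nitrogen-Bound Chain

This account rests on a few compounds, and the source may have more. Where it says the series, first, only, none or still open, it means among the compounds named here.

The measurements come from an ADME assay on RAW264.7 cells (Mus musculus) for cytotoxicity, read by resazurin assay, with a stated time of 48 h; a lower number here means that less compound is tolerated, a higher number that more compound is tolerated. In this assay compound 1 `CCn1ncc2ccc(N/C(C)=C3\C(=O)C=C(C)OC3=O)cc21` gives > 100000 nM, which is a limit of the assay rather than a number. Compound 2 `C=CCn1ncc2ccc(N/C(C)=C3\C(=O)C=C(C)OC3=O)cc21` differs from compound 1 in one place (vinyl in place of methyl on a saturated chain carbon bound to an aromatic nitrogen). In this assay compound 2 gives > 100000 nM, again a limit. The step that the two limits leave unreadable from compound 1 to compound 2 therefore cannot be read in either direction. Compound 3 `CCn1ncc2cc(N/C(C)=C3\C(=O)C=C(C)OC3=O)ccc21` has the same atoms as compound 1 joined differently; the difference between the two cores is not broken down here. In this assay compound 3 gives > 100000 nM, once more a limit. Compound 4 `C=CCn1ncc2cc(N/C(C)=C3\C(=O)C=C(C)OC3=O)ccc21` carries the same change on the core of compound 3 (vinyl in place of methyl on a saturated chain carbon bound to an aromatic nitrogen), at the same place as the change from compound 1 to compound 2. Among the measured compounds shown here, the only evidence on this kind of change is the limit of > 100000 nM in this assay, at which 3 of the 3 values shown sit. Because of the limit of > 100000 nM in this assay, at which 3 of the 3 values shown sit, the step that the limit leaves unreadable from compound 3 to compound 4 is expected to be unreadable as well. The estimate for compound 4 is 150000 nM, which is expected to be reported only as a limit.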

Compound 4, half-maximal cytotoxic concentration: > 100000 nM
Compound 4: a limit, no number; the forecaster's own chance of this, stated with the estimate: 90%; the middle value is on the limit's open side.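

Among the compounds shown here, compound 3 and compound 4 each give only a limit in this assay, not a number, so no step between them can be read. The compounds shown leave open whether vinyl in place of methyl changes how much compound the cells tolerate, and at what concentration any of these four compounds would harm them.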